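The compounds below may be only part of what the source reports. "The series", "measured", "known", "first", "only" and "open" are said of these compounds alone.

Going by the values given here, in a functional assay on Gurav cells (Homo sapiens) for inhibition, read by sulforhodamine B assay (on this read-out lower numbers stand for stronger inhibition of growth and higher numbers for weaker inhibition of growth), compound 2 `Oc1cccc2[nH]c(-c3ccc(-c4ccc(-c5ccc(OC(F)(F)F)cc5)cc4)cc3)nc12` gives 3600 nM, the highest of the three numbers so far. Compound 1 `COc1ccc(-c2ccc(-c3ccc(-c4nc5cc(C)ccc5[nH]4)cc3)cc2)cc1OC` gives 1310 nM, and compound 3 `COc1ccc(-c2ccc(-c3ccc(-c4nc5c(O)cccc5[nH]4)cc3)cc2)cc1OC` gives 1110 nM. Compound 4 `Cc1ccc2[nH]c(-c3ccc(-c4ccc(-c5ccc(OC(F)(F)F)cc5)cc4)cc3)nc2c1` has not yet been measured and differs from compound 2 in one place: 5-methyl-1H-benzimidazol-2-yl in place of 4-hydroxy-1H-benzimidazol-2-yl on an aromatic carbon. The same exchange, run in the opposite direction, is seen in a 1.2-fold lower number from compound 1 to compound 3 (0.07 log units; within the scatter), a step within the scatter. The other measured step, a 3.2-fold lower number from compound 2 to compound 3 (0.51 log units; beyond the scatter), exchanges 4-(trifluoromethoxy)phenyl for 3,4-dimethoxyphenyl and leaves the changing group untouched. No step beyond the scatter is therefore expected in this assay. The expected step is a 1.1-fold higher number from compound 2 to compound 4 (0.05 log units; within the scatter). For compound 4 the estimated value is 4000 nM, with an expected range of 1800 nM to 9000 nM.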

Compound 4, concentration for 50% growth inhibition: 11000 nM
For compound 4 the middle estimate is 2.8-fold (0.44 log units) below the measured one, and the stated range ends below it.
By their numbers in this assay, from the lowest: compounds 3 and 1 (each within the scatter of the next); then compound 2; then compound 4.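

In this assay, the exchange of 4-hydroxy-1H-benzimidazol-2-yl for 5-methyl-1H-benzimidazol-2-yl now gives a step beyond the scatter with the 4-(trifluoromethoxy)phenyl group in place, a 3.1-fold higher number from compound 2 to compound 4 (0.49 log units; beyond the scatter). Even so, its two readings do not differ by more than two such steps can scatter: the same change on two cores in this assay, a 1.2-fold lower number (0.07 log units; within the scatter) from compound 1 to compound 3 and a 3.1-fold lower number (0.49 log units; beyond the scatter) from compound 4 to compound 2, 2.6-fold (0.41 log units) apart, within the scatter of two such steps. The exchange of the aryl group also reads larger on the second core, an 8.4-fold higher number from compound 1 to compound 4 (0.92 log units; beyond the scatter), and the same caution holds: the same change on two cores in this assay, a 3.2-fold lower number (0.51 log units; beyond the scatter) from compound 2 to compound 3 and an 8.4-fold lower number (0.92 log units; beyond the scatter) from compound 4 to compound 1, 2.6-fold (0.41 log units) apart, within the scatter of two such steps.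

The compounds shown carry only 4-hydroxy and 5-methyl, so the effect of the group cannot be separated from that of its position. Going by these compounds, what an amine or a carboxylic acid would do in that place stays open.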